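Adding a Methyl Group on the Ring Nitrogen

The source may report more compounds than this note shows. Statements on the series, on what has been measured and on what is new or still open speak of the compounds shown alone.

Compound 1, `O=C1CCC(Cc2ccc(C(F)(F)F)cc2)C(=O)N1`, in a functional assay on the whole organism with Mus musculus as the target, in the maximal electroshock model (a higher number here means that more compound is needed for the effect, a lower number that less compound is needed), gives 126 mg/kg. Compound 2, `O=C1CCC(Cc2ccc(Br)cc2)C(=O)N1`, gives 279 mg/kg. Compound 3, `CN1C(=O)CCC(Cc2ccccc2Br)C1=O`, gives 474 mg/kg.

All three compounds share a core in which a six-membered non-aromatic ring with one nitrogen carries a benzyl-type side group. Compound 2 stands well apart from compound 1: a 2.2-fold higher number from compound 1 to compound 2 (0.35 log units; beyond the scatter). Against compound 3, the number of compound 2 lies within the usual scatter, so no order between the two can be drawn.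

The next compound, compound 4, `CN1C(=O)CCC(Cc2ccc(Br)cc2)C1=O`, differs from compound 2 in one place: methyl in place of hydrogen on an amide-type nitrogen in a ring. Among the measured compounds shown here, compound 3 carries the same methyl on that nitrogen, but it also bears its bromo in a different position on the aromatic ring, so no single step in the measured set isolates this change. For the measured compounds named here, the only measured step, from compound 1 to compound 2, concerns the aromatic substituent and does not bear on the nitrogen. With compound 3 giving 474 mg/kg and compound 2 giving 279 mg/kg, the two numbers lying within the scatter, the methyl is not expected to move the number beyond the scatter. Compound 4 is therefore estimated at 330 mg/kg, within 150 mg/kg to 750 mg/kg, meaning an expected step of a 1.2-fold higher number from compound 2 to compound 4 (0.07 log units; within the scatter).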

Compound 4, dose for half-maximal effect: 162 mg/kg
Beside the measured number, compound 4's estimate is 2.0-fold (0.31 log units) above it, within the range that was stated.
By their numbers in this assay, from the lowest: compounds 1, 4, 2 and 3 (each within the scatter of the next, the first and the last beyond it).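

Among the compounds shown here, compound 4 and compound 2 form the first pair that differs only at the amide-type nitrogen in the ring, so the effect of this change can now be read on its own in this assay. Methyl in place of hydrogen gives a 1.7-fold lower number from compound 2 to compound 4 (0.24 log units; within the scatter) and, since that step stays within the usual scatter, the pair shows no real difference: the amide hydrogen can be replaced by this small carbon group without a shift that repeated measurements could distinguish from noise, at least with a bromo group on the aromatic ring as in compound 2. No measurement is available here that would explain this outcome.

The compounds shown leave open whether the same methyl would behave in the same way on the core of compound 1, which carries trifluoromethyl in place of bromo. They also leave open how far this nitrogen accepts something larger, such as an ethyl group, a longer chain or a chain ending in an amine.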